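The source may report more compounds than this note shows. Statements on the series, on what has been measured and on what is new or still open speak of the compounds shown alone.

Notes on the series. Compound 1 `CCCn1c(=O)[nH]c2nc(-c3ccc(S(=O)(=O)N4CCN(C)CC4)cc3)[nH]c2c1=O`, compound 2 `CCCn1c(=O)[nH]c2nc(-c3ccc(S(=O)(=O)N4CCN(Cc5ccc(Br)cc5)CC4)cc3)[nH]c2c1=O` and compound 3 `CCCn1c(=O)[nH]c2nc(-c3ccc(S(=O)(=O)N4CCN(c5ccc(Cl)cc5F)CC4)cc3)[nH]c2c1=O` share one core and differ only in the group on the amine nitrogen in a ring. In an assay on CHO cells for displacement of a labelled ligand from adenosine receptor A3 (Homo sapiens), read by scintillation counting, with a stated time of 45 min, in the presence of a further agent that is not named here (a higher number here means a weaker inhibitor, a lower number a stronger inhibitor), compound 1 gives > 1000 nM, which is a limit of the assay and not a number. Compound 2 gives > 1000 nM in this assay, again a limit. Compound 3 gives > 1000 nM in this assay, also a limit. Compound 3 thus stands with the other two at the limit of > 1000 nM in this assay, at which 3 of the 3 values shown sit. The steps a step that the two limits leave unreadable from compound 1 to compound 2, a step that the two limits leave unreadable from compound 1 to compound 3 and a step that the two limits leave unreadable from compound 2 to compound 3 are unreadable, since the two limits bound them from neither side.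

Compound 4 `CCCn1c(=O)[nH]c2nc(-c3ccc(S(=O)(=O)N4CCN(c5ccccc5F)CC4)cc3)[nH]c2c1=O` is not yet measured. It differs from compound 3 by hydrogen in place of chloro on an aromatic carbon. Within the data shown here, the measured steps bear on it only by showing that a methyl, a 4-bromobenzyl and a 4-chloro-2-fluorophenyl at that nitrogen all leave the compound at the limit; no step of readable size exists on which to expect a gain or loss in this assay. The expectation is that compound 4 is reported again as a limit. Compound 4 is estimated at 3000 nM, with a range from 800 nM to 20000 nM. The estimated step that the limit leaves unreadable from compound 3 to compound 4 is expected to be no more than the scatter.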

Compound 4, inhibition constant: > 1000 nM
Compound 4 ended at the assay's limit; the forecaster's own chance of this, stated with the estimate: 80%; the middle value is on the limit's open side.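

Compound 4 gives > 1000 nM in this assay, a limit of the assay and not a number. No new step can be read between compound 4 and compound 1, compound 2 or compound 3, since all four stand at the same limit: the limit of > 1000 nM in this assay, at which 4 of the 4 values shown sit.

The compounds shown leave open how far each lies beyond that limit, and whether any group on the amine nitrogen in a ring gives a readable value.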